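The compounds below may be only part of what the source reports. "The series", "measured", "known", "first", "only" and "open" are said of these compounds alone.

Of the compounds shown here, two have numbers so far. Compound 1 `Cc1cccc(CN2CC=C(CCC(=O)NO)C2=O)c1` gives 1990 nM in a functional assay on MDA-MB-231 cells (Homo sapiens) for inhibition, read by sulforhodamine B assay (on this read-out higher numbers stand for weaker inhibition of growth and lower numbers for stronger inhibition of growth), the higher of the two; compound 2 `O=C(CCC1=CCN(Cc2ccc(F)cc2)C1=O)NO` gives 1940 nM in this assay, a gap within the scatter, so neither is ordered above the other. Compound 3 `O=C(CCC1=CCN(Cc2cccc(Br)c2)C1=O)NO` has not been measured; it differs from compound 1 by bromo in place of methyl on an aromatic carbon. Within the data shown here, no pair of measured compounds differing in one place exists to anchor this change. The step to compound 3 is expected to be a 1.1-fold lower number from compound 1 to compound 3 (0.04 log units; within the scatter), not beyond the scatter in either direction. Compound 3 is estimated at 1800 nM, range 800 nM to 4000 nM.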

Compound 3, concentration for 50% growth inhibition: 1990 nM
The estimate for compound 3 lay 1.1-fold (0.04 log units) below the measured number; the measured number falls inside the stated range.
By their numbers in this assay, from the lowest: compounds 2, 1 and 3 (each within the scatter of the next).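

The series now has its first step at this position: with bromo in place of methyl on an aromatic carbon, meta to a large group, this assay gives no change at the digits printed from compound 1 to compound 3 (within the scatter). Methyl and bromo are therefore not told apart here, so this position accepts either group without a step beyond the scatter. No measurement at hand bears on why the two groups read alike. As far as these compounds go, an amine or a carboxylic acid at this place remains open, as does a longer chain such as propyl. From the compounds shown here alone, whether this step would look the same on another cell line also remains open.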